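This account rests on a few compounds, and the source may have more. Where it says the series, first, only, none or still open, it means among the compounds named here.

Compound 1, `ClCc1cccc(Cn2cnc3c(Cl)nc(Cl)nc32)c1`: 1860 nM
Compound 2, `Nc1nc(Cl)c2ncn(Cc3ccccc3CCl)c2n1`: 2240 nM
Compound 3, `ClCc1ccccc1Cn1cnc2nc(Cl)nc(Cl)c21`: 1200 nM

All three compounds were tested in a functional assay on UACC-62 cells (Homo sapiens) for cytotoxicity, read by sulforhodamine B assay, with a stated time of 48 h; on this read-out lower numbers stand for stronger inhibition of growth and higher numbers for weaker inhibition of growth. On these numbers compound 2 stands at the highest of the three, with 2240 nM. The nearest to it is compound 1, whose 1860 nM lies within the usual scatter of repeated measurements; the furthest is compound 3, whose 1200 nM also lies within that scatter. Going by the values given here, the three values therefore cannot be told apart with any confidence, and no pair of measured compounds differs in only one place, so no measured step is available to lean on.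

Compound 4, `ClCc1ccccc1Cn1cnc2c(Cl)ncnc21`, has not yet been measured. It differs from compound 2 in a single spot: hydrogen in place of amino on an aromatic carbon. The amino group leaves and a hydrogen enters on an aromatic carbon of the six-membered aromatic ring, between two ring nitrogen atoms.

With no measured step of this kind in hand, the step from compound 2 to compound 4 in this assay is expected to be small, a 1.5-fold lower number from compound 2 to compound 4 (0.17 log units; within the scatter), most likely within the scatter and, if anything, toward a slightly lower number. Compound 4 is thus estimated at 1500 nM, with a range from 600 nM to 4000 nM.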

Compound 4, concentration for 50% growth inhibition: 3310 nM
Compound 4: middle estimate off by 2.2-fold (0.34 log units), on the low side; low and high end bracket the measured number.
By their numbers in this assay, from the lowest: compounds 3, 1, 2 and 4 (each within the scatter of the next, the first and the last beyond it).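

Going by these compounds alone, this is the first measured step in the set that changes a single place: in this assay, hydrogen in place of amino on the aromatic carbon between two ring nitrogen atoms gives a 1.5-fold higher number from compound 2 to compound 4 (0.17 log units; within the scatter), the only direct reading of this position so far. A step of that size cannot be told apart from the variation between repeated measurements, so in these cells the amino group can be removed without a measurable change in growth inhibition, and the hydrogen-bond donor and acceptor counted with it leave no clear trace in the number. No other data on these compounds bear on this step, and it therefore comes with no explanation. From the compounds shown here alone, what stays open is whether a different group on this same carbon, such as a methoxy group, a methylamino group or a longer amine, would move the number beyond the scatter. Also open, going by these compounds, is whether the same swap would stay this small with other groups on the core or in a different cell line.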